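A few compounds are considered here, and "the series" means these few. Any claim that something is new, unique, unknown or untested is made for them only; others in the source may bear on it.

Values in a functional assay on L1210 cells (Mus musculus) for inhibition (a lower number here means a stronger inhibitor, a higher number a weaker inhibitor), for the measured compounds
- compound 1 `C#CCN(Cc1ccc2nc(C)nc(O)c2c1)c1ccccc1` gives > 6500 nM (a limit)
- compound 2 `C#CCN(Cc1ccc2nc(C)nc(O)c2c1)c1ccc(C(=O)c2ccccc2)cc1` gives 7700 nM
- compound 3 `C#CCN(Cc1ccc2nc(C)nc(O)c2c1)c1ccc(S(N)(=O)=O)cc1` gives 20000 nM

Of the two actual numbers, compound 3 has the higher (20000 nM), and the gap is a 2.6-fold higher number from compound 2 to compound 3 (0.41 log units; beyond the scatter). The next change leads to compound 4 `C#CCN(Cc1ccc2nc(C)nc(O)c2c1)c1ccc(S(=O)(=O)N2CCN(C)CC2)cc1`, with 4-methylpiperazin-1-yl in place of amino on a sulfonyl sulfur. Among the compounds with values here, no measured step alters this sulfonyl sulfur. The closest evidence is the modest 2.6-fold higher number from compound 2 to compound 3 (0.41 log units; beyond the scatter), which replaces the whole sulfamoyl group, while steps from compound 1 have no readable size. A modest shift to a lower number is therefore expected, estimated as a 1.7-fold lower number from compound 3 to compound 4 (0.22 log units; within the scatter). For compound 4 the estimated value is 12000 nM, with an expected range from 4500 nM to 30000 nM.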

Compound 4, half-maximal inhibitory concentration: > 10000 nM
Compound 4 ended at the assay's limit; the forecaster's own chance of this, stated with the estimate: 20%; the middle value is on the limit's open side.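

In this assay, within the data shown here, compound 4 gives > 10000 nM, which is a limit of the assay and the first reading for a change on the sulfonyl sulfur. The steps to compound 4 from compound 3 and from compound 1 cannot be read, so the effect of 4-methylpiperazin-1-yl in place of amino remains unsized. Among these compounds, the only readable comparison is with the benzoyl group, an at least 1.2-fold higher number from compound 2 to compound 4 (0.11 log units; that floor lies within the scatter).

Open, on these data alone, is where compound 4 lies beyond its limit. Also open, as far as these compounds go, is how a dimethylamino group or a morpholin-4-yl ring on the sulfonyl sulfur would read.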